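Sulfonylurea series: ring variation on the sulfonyl sulfur

A few compounds are considered here, and "the series" means these few. Any claim that something is new, unique, unknown or untested is made for them only; others in the source may bear on it.

Measured compounds in this assay, a functional assay on the whole organism (6C3HED cells, Mus musculus) for inhibition, at a dose of 150 mg/kg by the oral route; a lower number here means less inhibition, a higher number more inhibition at the dose given (going by the name of the read-out):
compound 1, `O=C(Nc1ccc(Cl)cc1)NS(=O)(=O)c1ccc(Cl)s1`: 58%
compound 2, `CCc1ccc(S(=O)(=O)NC(=O)Nc2ccc(Cl)cc2)o1`: 57%
compound 3, `Cc1ccsc1S(=O)(=O)NC(=O)Nc1ccc(Cl)cc1`: 17%

Compound 3 stands lowest of the three values in this assay; the nearest is compound 2 and the furthest compound 1, both gaps beyond the scatter. Compound 4, `Cc1cc(S(=O)(=O)NC(=O)Nc2ccc(Cl)cc2)sc1C`, remains to be measured. Its change from compound 3: 4,5-dimethylthiophen-2-yl in place of 3-methylthiophen-2-yl on a sulfonyl sulfur.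

Among the compounds with values here, the steps that bear on this are a number 41 percentage points lower from compound 1 to compound 3 (beyond the scatter) and a number 40 percentage points lower from compound 2 to compound 3 (beyond the scatter), both large, and in both the group that now leaves was the one entering. Within the data shown here, no measured step places two methyl groups on the ring, so the size of the return is uncertain. A rise beyond the scatter is expected for compound 4, though not a full return to compound 1. Compound 4 is estimated at 35%, range 10% to 62%, which is expected to mean a number 18 percentage points higher from compound 3 to compound 4 (beyond the scatter).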

Compound 4, a percentage reported as inhibition, in the whole organism at one dose (the size of the read-out at that dose, not a potency): 42%
For compound 4 the middle estimate is 7 percentage points below the measured one; low and high end bracket the measured number.
By their numbers in this assay, from the lowest: compound 3; then compound 4; then compounds 2 and 1 (each within the scatter of the next).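

In this assay, the step of a number 25 percentage points higher from compound 3 to compound 4 (beyond the scatter) shows that the low result for 3-methylthiophen-2-yl does not extend to every methylated thiophen-2-yl group on the sulfonyl sulfur. The return is only partial: the 4,5-dimethylthiophen-2-yl group still gives a number 16 percentage points lower from compound 1 to compound 4 (beyond the scatter) and a number 15 percentage points lower from compound 2 to compound 4 (beyond the scatter) in the same comparison. No measurement at hand explains these steps.

Which of the two methyl groups in 4,5-dimethylthiophen-2-yl carries the rise remains open. So does the outcome with a methoxy group, an amine or a carboxylic acid on the ring.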